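A few compounds are considered here, and "the series" means these few. Any claim that something is new, unique, unknown or untested is made for them only; others in the source may bear on it.

Measured so far in a functional assay on NCI-H1975 cells (Homo sapiens) for antiproliferative activity, read by MTT assay, with a stated time of 72 h; a lower number here means a stronger inhibitor, a higher number a weaker inhibitor:
Compound 1, `COc1cc2ncnc(Nc3ccc(Cl)c(C(F)(F)F)c3)c2cc1OCCCCC(=O)Nc1ccc(S(N)(=O)=O)cc1`, gives 3220 nM.
Compound 2, `COc1cc2ncnc(Nc3ccc(F)c(Br)c3)c2cc1OCCCCC(=O)Nc1ccc(S(N)(=O)=O)cc1`, gives 31600 nM.
Compound 3, `NS(=O)(=O)c1ccc(NC(=S)Nc2ccc3ncnc(Nc4ccc(Cl)c(C(F)(F)F)c4)c3c2)cc1`, gives 11800 nM.

Compound 1 and compound 2 share one core; compound 3 carries another, and the difference between the two cores is not broken down here. From compound 1 to compound 2 the change is 3-bromo-4-fluorophenyl in place of 4-chloro-3-(trifluoromethyl)phenyl on a nitrogen on an aromatic ring, and it made a 9.8-fold higher number from compound 1 to compound 2 (0.99 log units; beyond the scatter). Compound 4, `NS(=O)(=O)c1ccc(NC(=S)Nc2ccc3ncnc(Nc4ccc(F)c(Br)c4)c3c2)cc1`, is not yet measured; it stands to compound 3 as compound 2 stands to compound 1, the same change in the same place: 3-bromo-4-fluorophenyl in place of 4-chloro-3-(trifluoromethyl)phenyl on a nitrogen on an aromatic ring. The change has been seen once only, on the other core, so its size is carried over with caution. In this assay a step of a 6.8-fold higher number from compound 3 to compound 4 (0.83 log units; beyond the scatter) is expected, resting on a 9.8-fold higher number from compound 1 to compound 2 (0.99 log units; beyond the scatter). Compound 4 is therefore estimated at 80000 nM, within 25000 nM to 300000 nM. A number this high may come back only as a limit.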

Compound 4, half-maximal inhibitory concentration: 9980 nM
The estimate for compound 4 lay 8.0-fold (0.90 log units) above the measured number; measured number below the stated range.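

In this assay, 3-bromo-4-fluorophenyl in place of 4-chloro-3-(trifluoromethyl)phenyl gave a 1.2-fold lower number from compound 3 to compound 4 (0.07 log units; within the scatter), so on this core the change has no readable effect. The step seen on the core of compound 1 did not carry over to the core of compound 3: the same change on two cores in this assay, a 9.8-fold higher number (0.99 log units; beyond the scatter) from compound 1 to compound 2 and a 1.2-fold lower number (0.07 log units; within the scatter) from compound 3 to compound 4, 12-fold (1.06 log units) apart, beyond the scatter of two such steps. Among these compounds, with a single pair on each core, this shows only that the step is not transferable between these two cores; it does not show which part of the difference between them is responsible, or how the change would behave on any other core.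

Still open, from the compounds shown here alone, is whether a urea in place of the thiourea of compound 3 and compound 4 would restore the step seen from compound 1 to compound 2. Also open, going by these compounds, is whether a nitrile on the aniline ring would behave alike on both cores.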